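The compounds below may be only part of what the source reports. "The series", "measured", "known", "first", "only" and "open" are said of these compounds alone.

Working notes on the series. Compound 1 `O=CN1N=C(c2ccc(F)cc2)CC1c1cn(-c2ccccc2)nc1-c1ccc(Cl)c(Cl)c1` gives 37.2% in a functional assay on the whole organism (strain Wistar) for inhibition, with Rattus norvegicus as the target, read by paw edema, with a stated time of 30 min, at a dose of 50 mg/kg by the oral route (a higher number here means more inhibition at the dose given (going by the name of the read-out), a lower number less inhibition), and stands nominally at the top of the three numbers shown, yet compound 2 `O=CN1N=C(c2ccc(Cl)cc2)CC1c1cn(-c2ccccc2)nc1-c1ccc(Cl)c(Cl)c1` at 35.1% and compound 3 `Clc1ccc(C2=NNC(c3cn(-c4ccccc4)nc3-c3ccc(Cl)c(Cl)c3)C2)cc1` at 33% both sit within the scatter of it: a number 2.1 percentage points lower from compound 1 to compound 2 (within the scatter) and a number 2.1 percentage points lower from compound 2 to compound 3 (within the scatter). Compound 4 `O=[N+]([O-])c1ccc(N2N=C(c3ccc(F)cc3)CC2c2cn(-c3ccccc3)nc2-c2ccc(Cl)c(Cl)c2)cc1` differs from compound 1 by 4-nitrophenyl in place of formyl on an amine nitrogen in a ring. Among the compounds with values here, only the step from compound 2 to compound 3 bears on this change, since it too alters the amine nitrogen in the ring, and it stayed within the scatter; no measured step brings in a 4-nitrophenyl group. The expectation for compound 4 is therefore no step beyond the scatter, a number 0.2 percentage points lower from compound 1 to compound 4 (within the scatter). Compound 4 is estimated at 37%, with a range from 25% to 49%.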

Compound 4, a percentage reported as inhibition, in the whole organism at one dose (the size of the read-out at that dose, not a potency): 45.7%
Beside the measured number, compound 4's estimate is 8.7 percentage points below it; the measured number falls inside the stated range.
By their numbers in this assay, from the lowest: compounds 3, 2, 1 and 4 (each within the scatter of the next, the first and the last beyond it).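

In this assay, the first aromatic group shown on the amine nitrogen in the ring, 4-nitrophenyl with 9 heavy atoms in place of formyl with 2, gives a number 8.5 percentage points higher from compound 1 to compound 4 (within the scatter). This position therefore accepts a much larger group, one bearing a six-membered aromatic ring, without a step beyond the scatter. Nothing measured here explains this reading.

Going by these compounds, whether an acetyl or a methyl group on this nitrogen would read the same remains open. So does the effect of an amine or a carboxylic acid in place of the nitro group on the new phenyl ring.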